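The source may report more compounds than this note shows. Statements on the series, on what has been measured and on what is new or still open speak of the compounds shown alone.

Measured so far:
compound 1 `N#Cc1c(O)nc(SCc2nc3ccccc3[nH]2)nc1-c1ccccc1`: 6.2 nM
compound 2 `CNc1nc(SCc2nc3ccccc3[nH]2)nc(-c2ccccc2)c1C#N`: 2.7 nM
compound 3 `N#Cc1c(Nc2ccccn2)nc(SCc2nc3ccccc3[nH]2)nc1-c1ccccc1`: 7.35 nM

In a functional assay on KB cells (Homo sapiens) for cytotoxicity, read by MTT assay, with a stated time of 3 days (on this read-out lower numbers stand for stronger inhibition and higher numbers for weaker inhibition), compound 2 gives 2.7 nM, the lowest of the three numbers. Compound 4 `N#Cc1c(NC(N)=S)nc(SCc2nc3ccccc3[nH]2)nc1-c1ccccc1` differs from it as follows: a group of 3 heavy atoms (1 carbon, 1 nitrogen, 1 sulfur; no ring) in place of one carbon atom, on a nitrogen on an aromatic ring. The change is on a nitrogen on an aromatic ring. Among the compounds with values here, only one measured step replaces this same methyl: a 2.7-fold higher number from compound 2 to compound 3 (0.43 log units; beyond the scatter). The other two steps, a 2.3-fold lower number from compound 1 to compound 2 (0.36 log units; beyond the scatter) and a 1.2-fold higher number from compound 1 to compound 3 (0.07 log units; within the scatter), are no larger. Within the data shown here, the entering group has no counterpart among the measured compounds, so a modest move to a higher number is expected in this assay. The expected step is a 2.2-fold higher number from compound 2 to compound 4 (0.35 log units; beyond the scatter). For compound 4 the estimated value is 6 nM, with an expected range of 2.5 nM to 16 nM.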

Compound 4, half-maximal inhibitory concentration: 3.2 nM
For compound 4 the middle estimate is 1.9-fold (0.27 log units) above the measured one, and the stated range covers the measured number.
By their numbers in this assay, from the lowest: compounds 2, 4, 1 and 3 (each within the scatter of the next, the first and the last beyond it).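

In this assay, the group of 3 heavy atoms is the only replacement of methyl on this nitrogen shown that stays within the scatter: a 1.2-fold higher number from compound 2 to compound 4 (0.07 log units; within the scatter). The entering group matters at this place, since the two larger groups are separated beyond the scatter, with a 2.3-fold lower number from compound 3 to compound 4 (0.36 log units; beyond the scatter). Against hydroxy on the aromatic carbon, the difference remains within the scatter: a 1.9-fold lower number from compound 1 to compound 4 (0.29 log units; within the scatter).

No evidence is available on what underlies these differences. From the compounds shown here alone, how an ethyl or a benzyl group on this nitrogen would read remains open.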